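The compounds below may be only part of what the source reports. "The series", "measured", "known", "first", "only" and "open" are said of these compounds alone.

Three compounds with a shared core, a ketone on a benzene ring joined through a three-carbon oxygen chain to a piperazine, have been measured in an assay on isolated protein for binding affinity to histamine H2 receptor (Homo sapiens); on this read-out lower numbers stand for stronger inhibition and higher numbers for weaker inhibition. Compound 1 `CCCCCC(=O)c1ccc(OCCCN2CCNCC2)cc1` carries a free ring nitrogen and gives 14500 nM. Compound 2 `CCCCCC(=O)c1ccc(OCCCN2CCN(C(=O)C3CCC3)CC2)cc1` caps that nitrogen with a cyclobutylcarbonyl and gives 10200 nM, so a 1.4-fold lower number from compound 1 to compound 2 (0.15 log units; within the scatter). Compound 3 `CCCCCCCCC(=O)c1ccc(OCCCN2CCN(C(=O)OCC)CC2)cc1` carries an ethyl carbamate on the ring nitrogen and a longer octyl chain on the ketone; it gives 2690 nM, the lowest of the three numbers, a gap beyond the scatter to both compound 2 and compound 1.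

Compound 4 `CCOC(=O)N1CCN(CCCOc2ccc(C(=O)c3cccc(C)c3)cc2)CC1` keeps the ethyl carbamate of compound 3 and changes the ketone: 3-methylphenyl in place of octyl on a carbonyl carbon. Among the measured compounds shown here, the only measured step, from compound 1 to compound 2, concerns the ring nitrogen, not the carbonyl carbon, so nothing measured bears directly on this change. For the measured compounds named here, an aromatic ring replaces a flexible chain of nearly the same size, and with no comparable step to lean on, the expected change is small and could fall either way; the estimate is a 1.5-fold higher number from compound 3 to compound 4 (0.17 log units; within the scatter). Compound 4 is therefore expected to give about 4000 nM, within a range from 1000 nM to 16000 nM.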

Compound 4, inhibition constant: 3720 nM
The estimate for compound 4 lay 1.1-fold (0.03 log units) above the measured number; the range from low to high includes it.
By their numbers in this assay, from the lowest: compounds 3 and 4 (each within the scatter of the next); then compounds 2 and 1 (each within the scatter of the next).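

Among the compounds shown here, until now, only the ring nitrogen had been altered on its own, so this is the first look at the group on the carbonyl carbon. In this assay, 3-methylphenyl in place of octyl gives a 1.4-fold higher number from compound 3 to compound 4 (0.14 log units; within the scatter), which means that, with the ethyl carbamate on the ring nitrogen, an open chain with no ring and a six-membered aromatic ring of carbon only read alike at this position. No supporting information is available on why these two quite different groups give numbers within the scatter of each other.

As far as these compounds go, it remains open whether the methyl on the aromatic ring matters, and whether a plain phenyl, a longer chain, or a group of another kind, such as an amine or a carboxylic acid, would read the same at this carbonyl carbon. From the compounds shown here alone, compounds 2 and 3 differ in two places, so it also remains open how much of the distance between their numbers belongs to the ethyl carbamate and how much to the group on the carbonyl carbon.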